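Replacing the benzyl phenyl with a hydroxymethyl group

A few compounds are considered here, and "the series" means these few. Any claim that something is new, unique, unknown or untested is made for them only; others in the source may bear on it.

Three compounds share a dioxide core and differ in the amine substituent. In a functional assay on MOLT-4 cells (Homo sapiens) for cytotoxicity, read by MTT assay, with a stated time of 48 h (on this read-out higher numbers stand for weaker inhibition and lower numbers for stronger inhibition), compound 1 `COc1ccc(Nc2n[n+]([O-])c3ccccc3[n+]2[O-])cc1` gives 600 nM. Compound 3 `O=[N+]([O-])c1ccc(CNc2n[n+]([O-])c3ccccc3[n+]2[O-])cc1` gives 800 nM in this assay. Compound 2 `[O-][n+]1nc(NCc2ccccc2)[n+]([O-])c2ccccc21` gives 2200 nM in this assay and so stands highest of the three numbers; its nearest neighbour is compound 3, and a 2.8-fold lower number from compound 2 to compound 3 (0.44 log units; beyond the scatter) shows that adding a nitro group brought a modest gain beyond the scatter.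

Compound 4 `[O-][n+]1nc(NCCO)[n+]([O-])c2ccccc21` takes compound 2 as its parent. The change is hydroxymethyl in place of phenyl on a saturated chain carbon bound to a nitrogen on an aromatic ring. For the measured compounds named here, none of the measured steps removes the phenyl, so the only comparison available, the nitro step from compound 2 to compound 3, bears on it only indirectly and speaks to the other end of the series. Without a direct precedent, the account treats compound 4 with caution.

The number expected for compound 4 in this assay is 3000 nM, within a range from 1200 nM to 8000 nM. This estimate for compound 4 means a step of a 1.4-fold higher number from compound 2 to compound 4 (0.13 log units; within the scatter), which is expected to stay close to the scatter.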

Compound 4, half-maximal inhibitory concentration: 2600 nM
For compound 4 the middle estimate is 1.2-fold (0.06 log units) above the measured one; the range from low to high includes it.
By their numbers in this assay, from the lowest: compounds 1 and 3 (each within the scatter of the next); then compounds 2 and 4 (each within the scatter of the next).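

In this assay, the phenyl could be exchanged for hydroxymethyl on the saturated chain carbon with only a 1.2-fold higher number from compound 2 to compound 4 (0.07 log units; within the scatter), so an aromatic ring at this place is not needed to keep the number of compound 2. The earlier step had shown only that a nitro group on this phenyl shifts the number, whereas this change removes the ring itself and leaves a group with no ring, and the result stays within the scatter. No available measurement bears on why these two different groups give such similar numbers.

On these data alone, it remains open whether an amine, a carboxylic acid or a longer chain in place of hydroxymethyl would also stay within the scatter of compound 2. As far as these compounds go, it is also open whether any gain like that of the nitro step can be had once the phenyl is gone.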